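The source may hold more compounds than are shown below. What is called first, only, known or untested is meant among the compounds shown, and "the series" means these compounds.

Measured so far in an assay on isolated protein for agonist activity at Bile acid receptor (Homo sapiens), read by FRET; a higher number here means a larger maximal response, a lower number a smaller maximal response:
compound 1, `CC(C)c1onc(-c2c(Cl)cccc2Cl)c1COc1ccc(N(C)C(=O)c2ccc(C(=O)O)cc2)c(C(F)(F)F)n1`, gives 101%;
compound 2, `CC(C)c1onc(-c2c(Cl)cccc2Cl)c1COc1ccc(NC(=O)c2ccc(C(=O)O)cc2)c(C(F)(F)F)n1`, gives 109%;
compound 3, `CC(C)c1onc(-c2c(Cl)cccc2Cl)c1COc1ccc(N(C)C(=O)c2cccc(C(=O)O)c2)c(C(F)(F)F)n1`, gives 110%.

Compound 3 holds the highest of the three numbers, yet the gaps are small: compound 2 sits nearest and its value lies within the scatter of that of compound 3, and compound 1 is furthest with a number 9 percentage points higher from compound 1 to compound 3 (within the scatter). All three maximal responses therefore sit at the level of the control, with no ordering that can be trusted.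

Compound 4, `CC(C)c1onc(-c2c(Cl)cccc2Cl)c1COc1ccc(N(C)Cc2ccc(CCC(=O)O)cc2)c(C(F)(F)F)n1`, differs from compound 3 in one place: 4-(2-carboxyethyl)benzyl in place of (3-carboxyphenyl)carbonyl on a nitrogen on an aromatic ring. Among the compounds with values here, two measured steps touch parts of this change. The step of a number 8 percentage points higher from compound 1 to compound 2 (within the scatter) concerns the methyl on the amide-type nitrogen, which compound 4 keeps. The step of a number 9 percentage points higher from compound 1 to compound 3 (within the scatter) concerns where the carboxyl sits on the ring, which is moved again here. On these data alone, neither step covers the loss of the carbonyl or the arrival of the two-carbon chain carrying the acid, so that part of the change is untested. Since both known steps stayed within the scatter, compound 4 is expected to show a number 10 percentage points lower from compound 3 to compound 4 (within the scatter), i.e. no step beyond the scatter, with a wider band for the untested part. The estimate for compound 4 is 100%, between 75% and 120%.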

Compound 4, largest response reached (reported as efficacy), in percent of the reference or control that the assay uses: 96%
For compound 4 the middle estimate is 4 percentage points above the measured one; low and high end bracket the measured number.
By their numbers in this assay, from the lowest: compounds 4, 1, 2 and 3 (each within the scatter of the next, the first and the last beyond it).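

In this assay compound 4 gives 96% with 4-(2-carboxyethyl)benzyl on the nitrogen, so in this compound a large maximal response does not depend on a carbonyl attached to that nitrogen. Within the data shown here, the same kind of replacement reads as a number 14 percentage points lower from compound 3 to compound 4 (beyond the scatter) and as a number 5 percentage points lower from compound 1 to compound 4 (within the scatter) when the reference changes, so the only step beyond the scatter appears against one reference and not against the other, and the change is at most a modest one at this position. No measurement at hand explains why the step is beyond the scatter against only one of the two references.

Among these compounds, the single change removes the carbonyl and introduces the two-carbon chain bearing the acid together, so the contribution of each part stays unresolved. A 4-carboxybenzyl group on the same nitrogen, a benzoyl group carrying the two-carbon acid chain, or a tetrazole in place of the carboxylic acid would separate these parts and test whether the acid itself is needed for this level of response.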